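From bromo to chloro on compound 2

The compounds below may be only part of what the source reports. "The series", "measured", "known", "first", "only" and "open" are said of these compounds alone.

Within the data shown here, in a functional assay on A549 cells (Homo sapiens) for antiproliferative activity, read by MTT assay, with a stated time of 72 h (a lower number here means a stronger inhibitor, a higher number a weaker inhibitor), compound 1 (`NC1=NC2(CCOCC2)N(OCCCOc2ccccc2)C(N)=N1`) gives 1080 nM and compound 2 (`NC1=NC2(CCSCC2)N(OCCCOc2ccc(Br)cc2)C(N)=N1`) gives 740 nM and these two values lie within the scatter of each other, so compound 2 stands level with the only other measured compound. Compound 3 (`NC1=NC2(CCSCC2)N(OCCCOc2ccc(Cl)cc2)C(N)=N1`) differs from compound 2 by chloro in place of bromo on an aromatic carbon on an aromatic carbon, para to a large group. Among the measured compounds shown here, no measured pair isolates this change. The expected step of a 1.1-fold higher number from compound 2 to compound 3 (0.03 log units; within the scatter) in this assay stays within the scatter, with no direction foreseen. The estimate for compound 3 is 800 nM with an expected range from 350 nM to 1800 nM in this series.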

Compound 3, half-maximal inhibitory concentration: 580 nM
Beside the measured number, compound 3's estimate is 1.4-fold (0.14 log units) above it; low and high end bracket the measured number.
By their numbers in this assay, from the lowest: compounds 3, 2 and 1 (each within the scatter of the next).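

With this assay, chloro in place of bromo on an aromatic carbon, para to a large group, gives a 1.3-fold lower number from compound 2 to compound 3 (0.11 log units; within the scatter), so the two halogens cannot be told apart at this position. Among these compounds, compounds 2 and 3 form the only pair here that differs in one place, and this reading was not available from compounds 1 and 2. No measurement shown bears on the basis of this result. As far as these compounds go, whether an amine or a carboxylic acid on this aromatic carbon would give a step beyond the scatter remains open. So does the outcome of a longer chain at this position.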